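The compounds below may be only part of what the source reports. "The series", "measured", "known", "first", "only" and "open" are said of these compounds alone.

Compound 1 `O=C(CCN1CCN(c2ccc(C(F)(F)F)cc2)CC1)c1csc2ccc(F)cc12` is the starting point. In an ADME assay on Vero cells (Chlorocebus sabaeus) for cytotoxicity, with a stated time of 72 h (on this read-out lower numbers stand for stronger inhibition and higher numbers for weaker inhibition), compound 1 gives 896000 nM. Compound 2 `O=C(CCN1CCN(c2ccc([N+](=O)[O-])cc2)CC1)c1csc2ccc(F)cc12` carries one change, (nitro in place of trifluoromethyl on an aromatic carbon), and in this assay compound 2 gives 554000 nM. The step is a 1.6-fold lower number from compound 1 to compound 2 (0.21 log units; within the scatter), so the two numbers cannot be told apart.

Compound 3 `O=C(CCN1CCN(c2ccc(C(F)(F)F)cc2)CC1)c1ccc2ccccc2c1` keeps the trifluoromethyl-bearing end of compound 1 but has a different core, (naphthalen-2-yl in place of 5-fluoro-1-benzothiophen-3-yl on a carbonyl carbon). In this assay compound 3 gives 30100 nM, and the step is a 30-fold lower number from compound 1 to compound 3 (1.47 log units; beyond the scatter). Compound 3 therefore stands at the lowest number of the three, beyond the scatter from both compound 1 and compound 2.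

Compound 4 `O=C(CCN1CCN(c2ccc([N+](=O)[O-])cc2)CC1)c1ccc2ccccc2c1` is not yet measured. For the measured compounds named here, it differs from compound 3 by nitro in place of trifluoromethyl on an aromatic carbon, which is the same change as the one from compound 1 to compound 2: the place lines agree word for word. Going by the values given here, the only guide to its size is the one earlier example, where the step was a 1.6-fold lower number from compound 1 to compound 2 (0.21 log units; within the scatter), within the scatter. Among the compounds with values here, with the core of compound 3 there is no second example, so the expectation rests on that single pair. The estimated step from compound 3 to compound 4 is a 1.5-fold lower number from compound 3 to compound 4 (0.18 log units; within the scatter), chosen to lie close to the earlier one. The estimated value for compound 4 in this assay is 20000 nM, expected to fall between 8000 nM and 60000 nM.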

Compound 4, half-maximal inhibitory concentration: 74300 nM
The estimate for compound 4 lay 3.7-fold (0.57 log units) below the measured number, and the stated range ends below it.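

On the core of compound 3, putting nitro in place of trifluoromethyl gives a 2.5-fold higher number from compound 3 to compound 4 (0.39 log units; beyond the scatter), a modest but real rise, whereas the same change on the core of compound 1 left two numbers that cannot be told apart. Set side by side in this assay, the two results differ by more than repeated measurements would explain: the same change on two cores gives two different outcomes, so the step seen on one core could not simply be carried over to the other: the same change on two cores in this assay, a 1.6-fold lower number (0.21 log units; within the scatter) from compound 1 to compound 2 and a 2.5-fold higher number (0.39 log units; beyond the scatter) from compound 3 to compound 4, 4.0-fold (0.60 log units) apart, beyond the scatter of two such steps This shows that, for these compounds, the outcome of the change depends on the core it sits on, but it rests on only one pair of compounds per core and does not show why the cores differ, nor how the change would behave on any other core or in any other assay.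

From the compounds shown here alone, it remains open whether a nitrile, an amine or a carboxylic acid in place of trifluoromethyl on the same aromatic carbon would also give different outcomes on the two cores. Going by these compounds, it also remains open whether a third core would follow compound 1 and compound 2, follow compound 3 and compound 4, or behave differently from both pairs.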